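The source may hold more compounds than are shown below. What is called first, only, known or untested is meant among the compounds shown, and "the series" means these compounds.

Working notes on the series. All three measured compounds share one core and differ only in the group carried on the benzyl ring. Compound 1 `O=C(NCc1cn(Cc2ccc(F)cc2)nn1)c1cn(-c2ccccc2)nc1-c1ccccc1` gives 1600 nM in a functional assay on HeLa cells (Homo sapiens) for antiproliferative activity, read by sulforhodamine B assay, with a stated time of 48 h; a lower number here means a stronger inhibitor of growth, a higher number a weaker inhibitor of growth. Compound 2 `O=C(NCc1cn(Cc2ccc(Cl)cc2)nn1)c1cn(-c2ccccc2)nc1-c1ccccc1` gives 600 nM in this assay, and compound 3 `O=C(NCc1cn(Cc2ccc(C(F)(F)F)cc2)nn1)c1cn(-c2ccccc2)nc1-c1ccccc1` gives 1600 nM in this assay. Between them, a 2.7-fold lower number from compound 1 to compound 2 (0.43 log units; beyond the scatter); no change at the digits printed from compound 1 to compound 3 (within the scatter); a 2.7-fold higher number from compound 2 to compound 3 (0.43 log units; beyond the scatter). Compound 3 therefore stands level with compound 1, the two together carrying the highest numbers of the three, with compound 2 set apart from both by a modest margin.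

Compound 4 `COc1ccc(Cn2cc(CNC(=O)c3cn(-c4ccccc4)nc3-c3ccccc3)nn2)cc1` differs from compound 3 by methoxy in place of trifluoromethyl on an aromatic carbon. Among the measured compounds shown here, no measured step involves methoxy; the steps that bear on it are the three exchanges of the group at this position, which were either within the scatter or modest. An exchange at this position is thus expected to move this assay by no more than a modest amount, and with no direction known for methoxy the expected step is a 1.1-fold lower number from compound 3 to compound 4 (0.06 log units; within the scatter). For compound 4 the expected value in this assay is 1400 nM, with a range from 500 nM to 4500 nM.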

Compound 4, concentration for 50% growth inhibition: 6900 nM
Compound 4: middle estimate off by 4.9-fold (0.69 log units), on the low side; measured number above the stated range.
By their numbers in this assay, from the lowest: compound 2; then compounds 1 and 3 (each within the scatter of the next); then compound 4.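

Methoxy on this aromatic carbon gives the highest number of the four in this assay, and it stands beyond the scatter against each of the other groups: trifluoromethyl (a 4.3-fold higher number from compound 3 to compound 4 (0.63 log units; beyond the scatter)), fluoro (a 4.3-fold higher number from compound 1 to compound 4 (0.63 log units; beyond the scatter)) and chloro (a 12-fold higher number from compound 2 to compound 4 (1.06 log units; beyond the scatter)). Among the compounds shown here, the exchange against chloro is the first large step at this position, so the choice of group here can matter more than the fluoro, chloro and trifluoromethyl compounds alone showed. No measurement among those shown accounts for these steps.

Still open, from the compounds shown here alone, is whether this higher number is particular to methoxy or is shared by other groups attached through oxygen, such as hydroxy or ethoxy. The compounds shown also do not tell how an amine such as dimethylamino would read at this position.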